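Oxygen-to-sulfur exchange in a pair sitting at the limit

This account rests on a few compounds, and the source may have more. Where it says the series, first, only, none or still open, it means among the compounds named here.

Compound 1, `Cc1ncc2nccn2c1-c1ccc(Oc2nccc3occc23)cc1C(F)(F)F`: in an assay on cells for displacement of a labelled ligand from 5-hydroxytryptamine receptor 4 (Homo sapiens), read by scintillation counting, with a stated time of 90 min (on this read-out lower numbers stand for stronger inhibition and higher numbers for weaker inhibition), compound 1 gives > 10000 nM, a limit of the assay.
Compound 2, `FC(F)(F)c1cc(Oc2nccc3occc23)ccc1-c1cccc2nccn12`: in this assay compound 2 gives > 10000 nM, also a limit.

The step that the two limits leave unreadable from compound 1 to compound 2 cannot be read because both values sit at the limit of > 10000 nM in this assay, at which 2 of the 2 values shown sit. Compound 2 thus stands at the assay limit with no number. Compound 3, `FC(F)(F)c1cc(Oc2nccc3ccsc23)ccc1-c1cccc2nccn12`, differs from compound 2 by a group of 9 heavy atoms (7 carbon, 1 nitrogen, 1 sulfur; one five-membered aromatic ring with 1 hetero atom, one six-membered aromatic ring with 1 hetero atom) in place of a group of 9 heavy atoms (7 carbon, 1 nitrogen, 1 oxygen; one five-membered aromatic ring with 1 hetero atom, one six-membered aromatic ring with 1 hetero atom), on an oxygen on an aromatic ring. Among the compounds with values here, no measured step bears on this exchange, and the only measured step is unreadable. The estimate for compound 3 in this assay is 10000 nM, between 3000 nM and 30000 nM, most likely again a limit. The expected step is a number no higher from compound 2 to compound 3 (the limit leaves the size open).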

Compound 3, inhibition constant: 3700 nM
The estimate for compound 3 lay 2.7-fold (0.43 log units) above the measured number, within the range that was stated.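

Within the data shown here, compound 3 gives the first number in this set, since the earlier pair left only an unreadable step. In this assay, the group carrying 1 sulfur in place of the group carrying 1 oxygen, on an oxygen on an aromatic ring, gives an at least 2.7-fold lower number from compound 2 to compound 3 (0.43 log units; beyond the scatter), so this position responds to a change of a single ring atom. Going by these compounds, the true size of that step stays open because compound 2 sits at a limit: the limit of > 10000 nM in this assay, at which 2 of the 3 values shown sit.

On these data alone, whether the same exchange would lower the number on the core of compound 1 remains open. So does what an amine or a carboxylic acid at this position would give.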